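Fluoro for methoxy at the arylidene phenyl

A few compounds are considered here, and "the series" means these few. Any claim that something is new, unique, unknown or untested is made for them only; others in the source may bear on it.

Compound 3 `COc1ccc(/C=C2\S/C(=N\c3nc(-c4ccc(Cl)cc4)cs3)NC2=O)cc1` holds the lowest number of the three in a functional assay on SW-620 cells (Homo sapiens) for cytotoxicity, read by MTT assay, with a stated time of 72 h (on this read-out lower numbers stand for stronger inhibition and higher numbers for weaker inhibition), giving 50 nM. Compound 2 `Cc1ccc(/C=C2\S/C(=N\c3nc(-c4ccc(Cl)cc4)cs3)NC2=O)cc1` gives 890 nM, and compound 1 `COc1ccc(-c2cc(/N=C3\SCC(=O)N3c3cccc(OC)c3)cs2)cc1`, built on a different core, gives 3500 nM. Compound 4 `O=C1N/C(=N/c2nc(-c3ccc(Cl)cc3)cs2)S/C1=C\c1ccc(F)cc1` differs from compound 3 by fluoro in place of methoxy on an aromatic carbon. Going by the values given here, no measured step exchanges methoxy for fluoro. Among the compounds with values here, the only step at this position is an 18-fold lower number from compound 2 to compound 3 (1.25 log units; beyond the scatter), which shows that the group here moves the read-out strongly; fluoro is neither methyl nor methoxy, so the direction is not fixed by measurement. A higher number than compound 3 is therefore expected, without a return to the weakest numbers. For compound 4 the estimated step is an 8.0-fold higher number from compound 3 to compound 4 (0.90 log units; beyond the scatter). The expected value for compound 4 is 400 nM, with a range from 80 nM to 2000 nM.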

Compound 4, half-maximal inhibitory concentration: > 50000 nM
Compound 4 was reported as a limit (the forecaster's own chance of this, stated with the estimate: 5%); middle value at least 120-fold (2.09 log units) from the limit.
By their numbers in this assay, from the lowest: compound 3; then compound 2; then compound 1. At a limit, above all of these: compound 4.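

Compound 4 is reported only as a limit: the limit of > 50000 nM in this assay, at which 1 of the 4 values shown sits. The change from 4-methoxyphenyl to 4-fluorophenyl gives an at least 1000-fold higher number from compound 3 to compound 4 (3.00 log units; beyond the scatter), and fluoro in place of methyl gives an at least 56-fold higher number from compound 2 to compound 4 (1.74 log units; beyond the scatter), so fluoro ranks behind both earlier groups on this shared core. The earlier step showed only a gap between methoxy and methyl; this one substituent can also carry the read-out from the lowest number shown to the limit.

Going by these compounds, whether the low number depends on the oxygen of methoxy remains open; a hydroxy, ethoxy or amine group here would test this. On these data alone, how far beyond its limit compound 4 lies also remains open.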